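Swapping the Aryl Group in a Thiourea Series

The source may hold more compounds than are shown below. What is called first, only, known or untested is meant among the compounds shown, and "the series" means these compounds.

Compound 1, `CN(c1cc2ncc(=O)[nH]c2cc1NC(=S)NC(=O)c1ccc(F)cc1)C1CCCCC1`: 11400 nM in an ADME assay on Huh-7 cells (Homo sapiens) for cytotoxicity; on this read-out lower numbers stand for stronger inhibition and higher numbers for weaker inhibition
Compound 2, `COc1cc(C(=O)NC(=S)Nc2cc3[nH]c(=O)cnc3cc2N(C)C2CCCCC2)cc(OC)c1OC`: 15900 nM in this assay

Within the data shown here, only two compounds have been measured, and compound 2 sits alongside compound 1: the step of a 1.4-fold higher number from compound 1 to compound 2 (0.14 log units; within the scatter) lies within the scatter, so the two values cannot be told apart. Compound 3, `CN(c1cc2ncc(=O)[nH]c2cc1NC(=S)NC(=O)c1cccc2ccccc12)C1CCCCC1`, has not yet been measured. It differs from compound 2 in one place: naphthalen-1-yl in place of 3,4,5-trimethoxyphenyl on a carbonyl carbon. Among the measured compounds shown here, the one measured step that bears on this change is the earlier swap of the aryl group on the same carbonyl carbon, a 1.4-fold higher number from compound 1 to compound 2 (0.14 log units; within the scatter), which stayed within the scatter. On that evidence a further swap of the aryl group at this position is expected to leave the number about where it is, with no shift beyond the scatter, so a 1.2-fold lower number from compound 2 to compound 3 (0.09 log units; within the scatter) is the expected step. Compound 3 is therefore estimated at 13000 nM, within a range from 5000 nM to 35000 nM in this assay.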

Compound 3, half-maximal inhibitory concentration: 9980 nM
For compound 3 the middle estimate is 1.3-fold (0.11 log units) above the measured one; measured number inside the range.
By their numbers in this assay, from the lowest: compounds 3, 1 and 2 (each within the scatter of the next).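

Three different aryl groups have now stood on this carbonyl carbon, and in this assay the position still shows no measurable preference among them: the new steps are a 1.6-fold lower number from compound 2 to compound 3 (0.20 log units; within the scatter) and a 1.1-fold lower number from compound 1 to compound 3 (0.06 log units; within the scatter), both within the scatter. The latest change is a marked one in structure, since naphthalen-1-yl brings two six-membered aromatic rings of carbon only and no hydrogen-bond acceptors, whereas 3,4,5-trimethoxyphenyl has one such ring and three acceptors, yet the number does not move beyond the scatter. No measurement at hand offers a reason for this flat result.

On these data alone, all three groups are aromatic rings joined directly to the carbonyl carbon, so it remains open whether an open-chain group such as butyl, or a group carrying an amine or a carboxylic acid, would shift the number. Changes elsewhere on the shared core also remain untested by these compounds.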